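Three close values and one untested group

A few compounds are considered here, and "the series" means these few. Any claim that something is new, unique, unknown or untested is made for them only; others in the source may bear on it.

In a physicochemical assay for solubility, read by HPLC, in phosphate buffer, measured as kinetic solubility, at pH 7.4 (a lower number here means a less soluble compound, a higher number a more soluble compound), compound 1 (`CCC(=O)c1cc(-c2ccc(S(N)(=O)=O)cc2)n(-c2ccc(Cl)cc2)n1`) gives 41900 nM, compound 2 (`NS(=O)(=O)c1ccc(-c2cc(C(=O)N3CC4CC4C3)nn2-c2ccc(Cl)cc2)cc1`) gives 36600 nM and compound 3 (`NS(=O)(=O)c1ccc(-c2cc(C(=O)N3CCCCC3)nn2-c2ccc(Cl)cc2)cc1`) gives 65900 nM. On these numbers, compound 3 cannot be told apart from the other two. The next step leads to compound 4 (`CN(C(=O)c1cc(-c2ccc(S(N)(=O)=O)cc2)n(-c2ccc(Cl)cc2)n1)C1CC(F)(F)C1`), with this change: (3,3-difluorocyclobutyl)(methyl)amino in place of piperidin-1-yl on a carbonyl carbon. In words, (3,3-difluorocyclobutyl)(methyl)amino takes the place of piperidin-1-yl on a carbonyl carbon.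

All three measured steps change the group at that same place, so all three bear on this one. They show a 1.1-fold lower number from compound 1 to compound 2 (0.06 log units; within the scatter), a 1.6-fold higher number from compound 1 to compound 3 (0.20 log units; within the scatter) and a 1.8-fold higher number from compound 2 to compound 3 (0.26 log units; within the scatter). None leaves the scatter, so no step beyond the scatter is expected in this assay. Among the compounds with values here, no measured compound carries the entering group, however, so the range must stay wide. The estimated change is a 1.5-fold lower number from compound 3 to compound 4 (0.17 log units; within the scatter). The estimated value for compound 4 is 45000 nM, with an expected range from 20000 nM to 100000 nM.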

Compound 4, solubility: 30900 nM
Compound 4: middle estimate off by 1.5-fold (0.16 log units), on the high side; low and high end bracket the measured number.
By their numbers in this assay, from the lowest: compounds 4, 2, 1 and 3 (each within the scatter of the next, the first and the last beyond it).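

In this assay, within the data shown here, (3,3-difluorocyclobutyl)(methyl)amino in place of piperidin-1-yl on a carbonyl carbon gives a 2.1-fold lower number from compound 3 to compound 4 (0.33 log units; beyond the scatter), a modest change and the only step at this place that leaves the scatter. The other two steps stay inside it, with a 1.2-fold lower number from compound 2 to compound 4 (0.07 log units; within the scatter) and a 1.4-fold lower number from compound 1 to compound 4 (0.13 log units; within the scatter), so among these four compounds only compound 3 and compound 4 stand clearly apart. Nothing on hand explains this difference.

The compounds shown leave open which part of the entering group goes with the lower number: the two fluorine atoms, the four-membered ring or the methyl. Cyclobutyl(methyl)amino, which has no fluorine, or morpholin-4-yl on the same carbonyl carbon would give further comparisons at this place.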